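This account rests on a few compounds, and the source may have more. Where it says the series, first, only, none or still open, it means among the compounds named here.

Working notes on the series, read in a functional assay on WI-38 VA13 cells (Homo sapiens) for cytotoxicity; a higher number here means that more compound is needed for the effect, a lower number that less compound is needed. For the measured compounds named here, compound 2 `CC(=O)Nc1ccc2nc(NC(=O)C3CCCCC3)sc2c1` gives 2.7 ug/mL, the only actual number so far. Compound 1 `O=C(Nc1ccc2nc(NC(=O)C3CCCCC3)sc2c1)c1ccc(Cl)cc1Cl` gives > 4 ug/mL, which is a limit of the assay and not a number.

The next change leads to compound 3 `Cn1nccc1C(=O)Nc1ccc2nc(NC(=O)C3CCCCC3)sc2c1`, with 1-methyl-1H-pyrazol-5-yl in place of methyl on a carbonyl carbon.

Going by the values given here, one measured step bears on this place, and it also concerns the group on that carbonyl carbon: an at least 1.4-fold lower number from compound 1 to compound 2 (0.17 log units; that floor lies within the scatter). Its size is known only as a floor, so it says little about how far a ring-bearing group can move the number in this assay. Compound 3 resembles compound 1 in carrying a ring at this place, but the pyrazole is a different ring from 2,4-dichlorophenyl. On that basis, no shift beyond the scatter is expected, with only a slight lean towards a higher number.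

The expected step is a 1.2-fold higher number from compound 2 to compound 3 (0.07 log units; within the scatter). Compound 3 is estimated at 3.2 ug/mL, with an expected range of 1.3 ug/mL to 7 ug/mL.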

Compound 3, half-maximal effective concentration: 0.58 ug/mL
Compound 3: the middle estimate sits 5.5-fold (0.74 log units) above what was measured; measured number below the stated range.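

At this carbonyl carbon the group can move the number beyond the scatter in this assay: a 4.7-fold lower number from compound 2 to compound 3 (0.67 log units; beyond the scatter), and the earlier step, a floor within the scatter, could not show that. Two ring-bearing groups also separate here, with an at least 6.8-fold lower number from compound 1 to compound 3 (0.83 log units; beyond the scatter), so carrying a ring at this place does not by itself set the number, and 1-methyl-1H-pyrazol-5-yl does not read like 2,4-dichlorophenyl. That second step is only a floor and its true size stays unknown, since compound 1 stands at a limit and not at a number: the limit of > 4 ug/mL in this assay, at which 1 of the 3 values shown sits.

The compounds shown leave open whether the lower number of compound 3 goes with the pyrazole ring itself or with the methyl it carries, which a pyrazole without that methyl would help to separate. Also open, from the compounds shown here alone, is how a plain phenyl group, free of chlorine, or an open chain ending in an amine would read at this carbonyl carbon in this assay, and so whether the ring is needed at all.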